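The source may report more compounds than this note shows. Statements on the series, on what has been measured and on what is new or still open speak of the compounds shown alone.

For the measured compounds named here, compound 1 `O=c1nc(N2CCN(NCC3CCCCC3)CC2)sc2c([N+](=O)[O-])cc(C(F)(F)F)cc12` is the only member of this small set with an actual number: in an ADME assay on Vero cells (Chlorocebus sabaeus) for cytotoxicity, read by MTT assay, with a stated time of 72 h (a lower number here means that less compound is tolerated, a higher number that more compound is tolerated), compound 1 gives 29.3 ug/mL. Compound 2 `O=c1nc(N2CCN(NCc3cccc(C(F)(F)F)c3)CC2)sc2c([N+](=O)[O-])cc(C(F)(F)F)cc12` reaches only a limit of the assay, giving > 64 ug/mL. Compound 3 `O=c1nc(N2CCN(NCc3ccc(Br)cc3)CC2)sc2c([N+](=O)[O-])cc(C(F)(F)F)cc12` likewise stops at a limit, giving > 64 ug/mL. Each of the two measured changes put an aromatic ring of carbon only in place of the cyclohexyl, and each moved the reading upward: an at least 2.1-fold higher number from compound 1 to compound 2 (0.33 log units; beyond the scatter) and an at least 2.1-fold higher number from compound 1 to compound 3 (0.33 log units; beyond the scatter). Between the two aromatic compounds the step is a step that the two limits leave unreadable from compound 2 to compound 3, because of the limit of > 64 ug/mL in this assay, at which 2 of the 3 values shown sit. Compound 4 `O=c1nc(N2CCN(Nc3ccc(OC(F)(F)F)cc3)CC2)sc2c([N+](=O)[O-])cc(C(F)(F)F)cc12` has not yet been measured. It differs from compound 1 as follows: 4-(trifluoromethoxy)phenyl in place of cyclohexylmethyl on an amine nitrogen. Once more a non-aromatic ring gives way to an aromatic one, so from the two measured steps a rise of at least modest size, reaching toward the limit, is expected, a 2.2-fold higher number from compound 1 to compound 4 (0.34 log units; beyond the scatter). For compound 4 the estimated value is 64 ug/mL, expected to lie between 30 ug/mL and 128 ug/mL.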

Compound 4, half-maximal cytotoxic concentration: > 64 ug/mL
Compound 4: only a limit was reported; the forecaster's own chance of this, stated with the estimate: 70%; the middle value sits exactly at the limit.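

In this assay, the rise seen with the benzyl-type groups of compound 2 and compound 3 also appears when the aromatic ring sits directly on the amine nitrogen, with no chain carbon in the new group, and carries 4-trifluoromethoxy rather than bromo or trifluoromethyl: an at least 2.1-fold higher number from compound 1 to compound 4 (0.33 log units; beyond the scatter). Compound 4 gives > 64 ug/mL, which is a limit of the assay and not a number. The steps to compound 4 from compound 2 and from compound 3 cannot be read, because all three compounds stop at the same limit: the limit of > 64 ug/mL in this assay, at which 3 of the 4 values shown sit.

The compounds shown do not separate the effect of the aromatic ring from that of the chain carbon, as a plain cyclohexyl on the amine nitrogen would. As far as these compounds go, whether the higher reading holds with a pyridine ring or with an amine on the phenyl ring also stays open.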